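Removing the aryl group from an amidine-type nitrogen

The source may report more compounds than this note shows. Statements on the series, on what has been measured and on what is new or still open speak of the compounds shown alone.

Of the compounds shown here, three sharing one core have been tested in an ADME assay on HEK293 cells (Homo sapiens) for cytotoxicity, read by MTT assay, with a stated time of 48 h; a lower number here means a stronger inhibitor, a higher number a weaker inhibitor. Compound 1 `COc1ccc(N/C(CCNC2=CC(=O)c3ccccc3C2=O)=N\S(=O)(=O)c2ccc(C)cc2)cc1OC` gives 60600 nM. Compound 2 `Cc1ccc(S(=O)(=O)/N=C(/CCNC2=CC(=O)c3ccccc3C2=O)Nc2cc(F)c(F)c(F)c2)cc1` gives 82600 nM, and compound 3 `COc1ccc(N/C(CCNC2=C(Br)C(=O)c3ccccc3C2=O)=N\S(=O)(=O)c2ccc(C)cc2)cc1OC` gives 35300 nM. Among these three numbers compound 1 stands second highest; its nearest neighbour is compound 2, with a 1.4-fold higher number from compound 1 to compound 2 (0.13 log units; within the scatter), and the furthest is compound 3, with a 1.7-fold lower number from compound 1 to compound 3 (0.23 log units; within the scatter). Both steps stay within the scatter, so the three compounds cannot be told apart on this read-out.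

Compound 4 `Cc1ccc(S(=O)(=O)/N=C(\N)CCNC2=CC(=O)c3ccccc3C2=O)cc1` is the next compound. It differs from compound 1 in one place: hydrogen in place of 3,4-dimethoxyphenyl on an amine nitrogen. Within the data shown here, no measured step removes this group outright; the closest comparison is the exchange of one aryl group for another, from compound 1 to compound 2, which stayed within the scatter. With only that to go on, the expectation for compound 4 is no step beyond the scatter, a 1.2-fold higher number from compound 1 to compound 4 (0.06 log units; within the scatter). Compound 4 is therefore estimated at 70000 nM, with a range from 30000 nM to 160000 nM.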

Compound 4, half-maximal inhibitory concentration: 63100 nM
Estimate against measurement, compound 4: 1.1-fold (0.05 log units) above, within the range that was stated.
By their numbers in this assay, from the lowest: compounds 3, 1, 4 and 2 (each within the scatter of the next, the first and the last beyond it).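

Until now this amine nitrogen had only seen one aryl group exchanged for another. Compound 4 shows that in this assay the aryl group can be removed altogether, taking an aromatic ring with it, and the number stays within the scatter (a 1.0-fold higher number from compound 1 to compound 4 (0.02 log units; within the scatter); a 1.3-fold lower number from compound 2 to compound 4 (0.12 log units; within the scatter)). On these compounds, then, neither 3,4-dimethoxyphenyl nor 3,4,5-trifluorophenyl on this nitrogen gives a difference from plain hydrogen that this read-out can detect, and nothing at hand accounts for that flat result.

Still open, from the compounds shown here alone, is whether a methyl group, a longer chain or a carboxylic acid on this nitrogen would read any differently. Also open, going by these compounds, is how bromo on the double-bonded ring carbon, as in compound 3, would read in a compound that has hydrogen on this nitrogen.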